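Aryl urea replacements in the cytotoxicity series

The compounds below may be only part of what the source reports. "The series", "measured", "known", "first", "only" and "open" are said of these compounds alone.

Compound 1 `O=C(Nc1ccc(Br)cc1)N[C@H]1CC[C@H](Oc2ccc(F)cc2)CC1`: in a functional assay on CRL2813 cells (Homo sapiens) for cytotoxicity, read by sulforhodamine B assay, with a stated time of 5 days (on this read-out lower numbers stand for stronger inhibition and higher numbers for weaker inhibition), compound 1 gives > 20000 nM, a limit of the assay.
Compound 2 `COc1ccccc1NC(=O)N[C@H]1CC[C@H](Oc2ccc(F)cc2)CC1`: compound 2 gives > 20000 nM, also a limit.
Compound 3 `O=C(Nc1ccccc1[N+](=O)[O-])N[C@H]1CC[C@H](Oc2ccc(F)cc2)CC1`: compound 3 gives 3500 nM.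

Among the compounds with values here, compound 3 thus holds the only numerical value in this assay; the other two sit at the limit of > 20000 nM in this assay, at which 2 of the 3 values shown sit. Compound 4 `CSc1cccc(NC(=O)N[C@H]2CC[C@H](Oc3ccc(F)cc3)CC2)c1` differs from compound 3 by 3-(methylsulfanyl)phenyl in place of 2-nitrophenyl on an amide-type nitrogen. Within the data shown here, the measured steps that bear on this change are an at least 5.7-fold lower number from compound 1 to compound 3 (0.75 log units; beyond the scatter) and an at least 5.7-fold lower number from compound 2 to compound 3 (0.75 log units; beyond the scatter): in both, the 2-nitrophenyl compound is the only one with a readable number, and leaving that group again is expected to raise the number. Compound 4 is therefore expected to give 14000 nM, in the range 4000 nM to 40000 nM, an expected step of a 4.0-fold higher number from compound 3 to compound 4 (0.60 log units; beyond the scatter), with a fair chance that only a limit is reported.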

Compound 4, half-maximal inhibitory concentration: 11100 nM
Beside the measured number, compound 4's estimate is 1.3-fold (0.10 log units) above it; the measured number falls inside the stated range.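

Moving away from 2-nitrophenyl on the amide-type nitrogen now has a readable size in this assay: a 3.2-fold higher number from compound 3 to compound 4 (0.50 log units; beyond the scatter). A nitro group is therefore not needed for a numerical value in this small set, since 3-(methylsulfanyl)phenyl also gives one. Against the two limit compounds only floors can be read, an at least 1.8-fold lower number from compound 2 to compound 4 (0.25 log units; that floor lies within the scatter) and an at least 1.8-fold lower number from compound 1 to compound 4 (0.25 log units; that floor lies within the scatter), and neither supports an order.

As far as these compounds go, the true size of those two gaps stays open: the limit of > 20000 nM in this assay, at which 2 of the 4 values shown sit. Also open is how an amine or a carboxylic acid in place of methylsulfanyl would read.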